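A few compounds are considered here, and "the series" means these few. Any claim that something is new, unique, unknown or untested is made for them only; others in the source may bear on it.

Working notes on the series. Of the compounds shown here, two of the shared core have been measured in an assay on NIH3T3 cells with Urotensin-2 receptor (Homo sapiens) as the target; on this read-out lower numbers stand for an effect already at smaller amounts and higher numbers for an effect only at larger amounts of compound. Compound 1 `CN(C)CCC(NC(=O)c1ccc(C(F)(F)F)cc1)c1ccc(Cl)cc1` gives 77.6 nM in this assay. Compound 2 `CCc1ccccc1C(=O)N[C@@H](CCN(C)C)c1ccc(Cl)cc1` gives 1020 nM in this assay, a number that lies beyond the scatter above that of compound 1. Among the compounds with values here, compound 1 thus stands at the lowest of the two numbers seen so far, with compound 2 as its only neighbour at a markedly higher value.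

The next compound to be measured is compound 3 `CN(C)CCC(NC(=O)c1ccc(N(C)C)cc1)c1ccc(Cl)cc1`. Compound 3 differs from compound 1 in one place: dimethylamino in place of trifluoromethyl on an aromatic carbon. Within the data shown here, no pair of measured compounds shows this change, so no step of known size can be carried over, and the expectation rests only on the position of compound 1 in this assay.

The step from compound 1 to compound 3 is estimated as a 3.9-fold higher number from compound 1 to compound 3 (0.59 log units; beyond the scatter), a move toward a higher number that is expected to go beyond the scatter, though with wide uncertainty. Compound 3 is therefore estimated at 300 nM in this assay, within a range from 60 nM to 2000 nM.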

Compound 3, half-maximal effective concentration: 1350 nM
Compound 3: middle estimate off by 4.5-fold (0.65 log units), on the low side, within the range that was stated.
By their numbers in this assay, from the lowest: compound 1; then compounds 2 and 3 (each within the scatter of the next).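

In this assay, replacing trifluoromethyl with dimethylamino on the aromatic carbon para to a large group gives a 17-fold higher number from compound 1 to compound 3 (1.24 log units; beyond the scatter), so the group at this position has a large bearing on the read-out while the rest of the shared core stays unchanged. Within the data shown here, this is the first step between compounds that differ in one place, and it gives the series its first measured size for a change at a single site. Among these compounds, no available measurement explains why this exchange moves the number so far.

As far as these compounds go, with only trifluoromethyl and dimethylamino compared at this position, it remains open whether the higher number is particular to dimethylamino or would also appear with a primary amine, a methoxy group, a nitrile or a single chlorine atom. From the compounds shown here alone, it is equally open whether a step of similar size would follow from the same exchange on a core carrying another group in place of the dimethylamino end of the side chain, such as a pyrrolidine or a longer chain.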